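Cyclohexyl for Isopropyl on the Benzimidazole-Free Core

The compounds below may be only part of what the source reports. "The series", "measured", "known", "first", "only" and "open" are said of these compounds alone.

Measured so far:
- compound 1, `Cc1ccc2nc([C@H](CC(C)C)N3C(=O)CN(c4ccc(Oc5ccccc5)cc4)C3=O)n(C)c2c1`: 65600 nM
- compound 2, `CC(C)C[C@@H](c1nc2ccc(C(=O)O)cc2n1C)N1C(=O)N(c2ccc(Oc3ccccc3)cc2)C(C)(C)C1=O`: 105000 nM
- compound 3, `CC[C@@H](c1nc2ccc(C(=O)O)cc2n1C)N1C(=O)CN(c2ccc(Oc3ccccc3)cc2)C1=O`: 210000 nM

In an assay on isolated protein for inhibition of Bile acid receptor (Homo sapiens), read by TR-FRET and LanthaScreen (on this read-out lower numbers stand for stronger inhibition and higher numbers for weaker inhibition), compound 1 gives the lowest number of the three. Compound 2 sits within the usual scatter of compound 1, so the two cannot be told apart; compound 3 lies beyond the scatter, with the higher number. No pair among these three differs in only one place, so no single measured step is known.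

Compound 4, `Cc1ccc2nc([C@H](CC3CCCCC3)N3C(=O)CN(c4ccc(Oc5ccccc5)cc4)C3=O)n(C)c2c1`, is built from compound 1 by one change: cyclohexyl in place of isopropyl on a saturated chain carbon, two bonds along the chain from an amide-type nitrogen in a ring and an aromatic carbon. Without a measured step of this kind, the expectation rests on the change alone, and a step of modest size, if any, seems reasonable, not clearly beyond the scatter in either direction. The number for compound 4 in this assay is expected to be 40000 nM, within a range from 10000 nM to 160000 nM, which is an estimated step of a 1.6-fold lower number from compound 1 to compound 4 (0.21 log units; within the scatter).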

Compound 4, half-maximal inhibitory concentration: 126000 nM
Beside the measured number, compound 4's estimate is 3.2-fold (0.50 log units) below it; the range from low to high includes it.
By their numbers in this assay, from the lowest: compounds 1, 2, 4 and 3 (each within the scatter of the next, the first and the last beyond it).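

In this assay, going by these compounds alone, the swap of isopropyl for cyclohexyl on this saturated chain carbon gives a 1.9-fold higher number from compound 1 to compound 4 (0.28 log units; within the scatter) and is the first single-place step measured in this set. In this one pair, the larger group, with its six-membered non-aromatic ring of carbon only, leaves the number indistinguishable from that of compound 1, so the position accepts this change without a clear shift in either direction. Nothing available here bears on the reason for this result.

The compounds shown leave open how this position would respond to a phenyl ring, an amine or a hydroxyl group at the end of the chain. They also leave open whether the same swap would read the same way on the core of compound 2.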